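Extending the chain while keeping the dimethylamino group

The source may report more compounds than this note shows. Statements on the series, on what has been measured and on what is new or still open speak of the compounds shown alone.

Measured so far:
compound 1, `CCCCCCCCCCCCCCCCc1nc(N2CCC2)c(C)c(C)c1O`, gives 70%
compound 2, `CCCCCCCCCCc1nc(N(C)C)c(C)c(C)c1O`, gives 52%

These two numbers come from a functional assay on cells (Lymphocyte), read by a luciferase reporter and ATP content, with a stated time of 48 h, tested at 10 uM; on this read-out higher numbers stand for a weaker effect at the one concentration tested and lower numbers for a stronger effect. Compound 2 holds the lower of the two, and its gap to compound 1 lies beyond the scatter, so compound 2 shows the stronger effect of the pair. Compound 2 and compound 1 differ in more than one place, so nothing can be said about either change on its own.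

Compound 3, `CCCCCCCCCCCCCCCCc1nc(N(C)C)c(C)c(C)c1O`, has not been measured. It differs from compound 2 by hexyl in place of hydrogen on a saturated chain carbon, ten or more bonds along the chain from an aromatic carbon. Going by the values given here, compound 1 carries a chain of this same length but a different amine group, so no single measured step speaks to the change alone. Given that compound 1 gives 70%, a modest rise toward that number seems plausible. Compound 3 is expected at 60%, within 42% to 78%. The step of a number 8 percentage points higher from compound 2 to compound 3 (within the scatter) is expected to be small and upward, hardly beyond the scatter.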

Compound 3, a percentage reported as activity, at one concentration (the size of the read-out at that concentration, not a potency): 79%
Compound 3: middle estimate off by 19 percentage points, on the low side; measured number above the stated range.
By their numbers in this assay, from the lowest: compound 2; then compounds 1 and 3 (each within the scatter of the next).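

With the dimethylamino group held fixed, hexyl in place of hydrogen on a saturated chain carbon, ten or more bonds along the chain from an aromatic carbon, gives a number 27 percentage points higher from compound 2 to compound 3 (beyond the scatter) in this assay and so weakens the effect at the one concentration tested. At the longer chain, dimethylamino in place of azetidin-1-yl on an aromatic carbon gives a number 9 percentage points higher from compound 1 to compound 3 (within the scatter) and so shows no effect of this amine change beyond the usual scatter. Nothing measured here points to a reason for either step.

Still open, on these data alone, is where a chain of intermediate length, such as dodecyl, would fall between compound 2 and compound 3. Also open, as far as these compounds go, is whether a larger ring amine such as piperidine would behave like the two amine groups at the longer chain.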